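A few compounds are considered here, and "the series" means these few. Any claim that something is new, unique, unknown or untested is made for them only; others in the source may bear on it.

Measured compounds:
Compound 1 `O=C(CCc1ccc(C(F)(F)F)cc1)Nc1ccc2nc(N3CCC3)ccc2c1` — 56 nM
Compound 2 `CC(C)N(C)c1ccc2cc(NC(=O)CCc3ccc(C(F)(F)F)cc3)ccc2n1` — 140 nM
Compound 3 `NC1CCN(c2ccc3cc(NC(=O)CCc4ccc(C(F)(F)F)cc4)ccc3n2)C1` — 200 nM

In a functional assay on HEK293 cells for activation of melanin-concentrating hormone receptor 1 (Rattus norvegicus), read by inositol phosphate accumulation (on this read-out lower numbers stand for an effect already at smaller amounts and higher numbers for an effect only at larger amounts of compound), compound 3 gives the highest of the three numbers. Its nearest neighbour is compound 2, at a 1.4-fold higher number from compound 2 to compound 3 (0.15 log units; within the scatter), a gap that stays within the scatter; the step to compound 1 is larger, a 3.6-fold higher number from compound 1 to compound 3 (0.55 log units; beyond the scatter), and lies beyond it. Compound 1 also stands apart from compound 2 by a 2.5-fold higher number from compound 1 to compound 2 (0.40 log units; beyond the scatter).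

Compound 4 `O=C(CCc1ccc(C(F)(F)F)cc1)Nc1ccc2nc(N3CCCCCC3)ccc2c1` has not yet been measured. It differs from compound 3 in one place: azepan-1-yl in place of 3-aminopyrrolidin-1-yl on an aromatic carbon. All three measured steps bear on this position, since each of them swaps the amine substituent on the same aromatic carbon. Those steps were modest or within the scatter, and the ring amine of compound 1, which lacks the donor of compound 3, gave the lowest number seen. Compound 4 is therefore expected to return towards that range, with an estimated step of a 1.8-fold lower number from compound 3 to compound 4 (0.26 log units; within the scatter). For compound 4 the estimate in this assay is 110 nM, within a range from 30 nM to 400 nM.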

Compound 4, half-maximal effective concentration: 1800 nM
Estimate against measurement, compound 4: 16-fold (1.21 log units) below; measured number outside the range, above it.
By their numbers in this assay, from the lowest: compound 1; then compounds 2 and 3 (each within the scatter of the next); then compound 4.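

In this assay, among these compounds, azepan-1-yl shows that this aromatic carbon next to the ring nitrogen is far less forgiving than the earlier amines suggested: a 9.0-fold higher number from compound 3 to compound 4 (0.95 log units; beyond the scatter), a 13-fold higher number from compound 2 to compound 4 (1.11 log units; beyond the scatter) and a 32-fold higher number from compound 1 to compound 4 (1.51 log units; beyond the scatter) are all beyond the scatter and exceed every step among the earlier compounds. Compound 1 and compound 4 both carry a ring amine without a hydrogen-bond donor, so the absence of a donor does not by itself give a low number at this position. Among the compounds shown here, nothing available explains why this ring raises the number so far.

The compounds shown leave open whether the number climbs steadily with ring size or rises only with the seven-membered ring, a question piperidin-1-yl could address. Pyrrolidin-1-yl, without the amino group, could separate the effect of the five-membered ring from that of its amine.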